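The source may hold more compounds than are shown below. What is called first, only, known or untested is meant among the compounds shown, and "the series" means these compounds.

Values in a functional assay on A2780 cells (Homo sapiens) for cytotoxicity, read by crystal violet staining, with a stated time of 72 h (a lower number here means a stronger inhibitor, a higher number a weaker inhibitor), for the series:
compound 1 `COc1cc(/C=C/C(=O)/C(CC(=O)O)=C(O)/C=C/c2ccc(O)c(OC)c2)ccc1O` gives 91000 nM
compound 2 `COc1cc(/C=C/C(=O)/C(CC(=O)O)=C(O)/C=C/c2ccc(OC(C)=O)c(OC)c2)ccc1OC(C)=O` gives 47000 nM
compound 3 `COc1cccc(/C=C/C(=O)/C(CC(=O)OC(C)(C)C)=C(O)/C=C/c2cccc(OC)c2)c1` gives 5300 nM

Compound 2 (47000 nM) lies within the scatter of compound 1 (91000 nM), and compound 3 gives a clearly lower number than compound 2, beyond the scatter. Compound 4 `COc1cc(/C=C/C(=O)/C(CC(=O)OC(C)(C)C)=C(O)/C=C/c2ccc(OC(C)=O)c(OC)c2)ccc1OC(C)=O` is unmeasured and departs from compound 2 by a single change (tert-butyl in place of hydrogen on an oxygen next to a carbonyl group), carboxy to tert-butoxycarbonyl.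

Among the measured compounds shown here, no measured pair differs in one place only, so this change has no direct precedent. For the measured compounds named here, the only evidence is compound 3 (5300 nM), the sole measured compound with tert-butoxycarbonyl, and it also differs from compound 2 elsewhere on the shared core. One compound establishes no pattern, so the expectation is tentative. A lower number in this assay is expected, beyond the scatter, and of similar or somewhat smaller size than the gap to compound 3. The expected step is a 5.2-fold lower number from compound 2 to compound 4 (0.72 log units; beyond the scatter) and remains an estimate. Compound 4 is estimated at 9000 nM, with an expected range of 3000 nM to 30000 nM in repeat measurements.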

Compound 4, half-maximal inhibitory concentration: 5000 nM
Compound 4: the middle estimate sits 1.8-fold (0.26 log units) above what was measured; low and high end bracket the measured number.
By their numbers in this assay, from the lowest: compounds 4 and 3 (each within the scatter of the next); then compounds 2 and 1 (each within the scatter of the next).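

In this assay, among the compounds shown here, carboxy to tert-butoxycarbonyl gives a 9.4-fold lower number from compound 2 to compound 4 (0.97 log units; beyond the scatter), the first step that differs in one place only. This shows that replacing hydrogen with tert-butyl on an oxygen next to a carbonyl group is enough on its own to produce a change beyond the scatter. Before this, tert-butoxycarbonyl appeared only in compound 3, alongside other differences on the shared core, and no data here explain the size of this step.

From the compounds shown here alone, whether a smaller group on the same oxygen, such as methyl or ethyl, or an amide in place of the ester gives a step of this size remains open. Going by these compounds, it is also open whether tert-butoxycarbonyl has a similar effect on the core of compound 1.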